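The source may hold more compounds than are shown below. What is called first, only, known or untested is meant among the compounds shown, and "the series" means these compounds.

In a functional assay on A549 cells (Homo sapiens) for inhibition, read by MTT assay, with a stated time of 48 h (on this read-out higher numbers stand for weaker inhibition and lower numbers for stronger inhibition), compound 1 `COc1cccc(C(c2c[nH]c3ccc(Br)cc23)c2c[nH]c3ccc(Br)cc23)c1OC` gives 100000 nM and compound 2 `COc1ccc(OC)c(C(c2c[nH]c3ccc(Br)cc23)c2c[nH]c3ccc(Br)cc23)c1` gives 10000 nM, so compound 2 holds the lower of the two numbers. Compound 3 `CN(C)c1ccc(C(c2c[nH]c3ccc(Br)cc23)c2c[nH]c3ccc(Br)cc23)cc1` is next, with one change from compound 2: 4-(dimethylamino)phenyl in place of 2,5-dimethoxyphenyl on a saturated chain carbon bound to two aromatic carbons. For the measured compounds named here, only one measured step bears on this, a 10-fold lower number from compound 1 to compound 2 (1.00 log units; beyond the scatter), and it swaps one dimethoxyphenyl group for another at the same place. It shows that this group can matter, but it gives no direction for a 4-(dimethylamino)phenyl group, so no shift beyond the scatter is expected. The expected change is no change at the digits printed from compound 2 to compound 3 (within the scatter). Compound 3 is expected at 10000 nM, with an estimated range from 2500 nM to 40000 nM.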

Compound 3, half-maximal inhibitory concentration: 25000 nM
The estimate for compound 3 lay 2.5-fold (0.40 log units) below the measured number, and the stated range covers the measured number.
By their numbers in this assay, from the lowest: compound 2; then compound 3; then compound 1.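

In this assay the change to 4-(dimethylamino)phenyl gives a 2.5-fold higher number from compound 2 to compound 3 (0.40 log units; beyond the scatter) and, against the other dimethoxyphenyl group, a 4.0-fold lower number from compound 1 to compound 3 (0.60 log units; beyond the scatter). So at this place on the saturated chain carbon, a group carrying nitrogen instead of oxygen is tolerated, and dimethoxyphenyl is not uniformly better or worse: one such group gives a lower number than 4-(dimethylamino)phenyl, the other a higher one. Nothing available explains this order. Still open, as far as these compounds go, is how an unsubstituted phenyl, or a phenyl bearing a carboxylic acid, would compare at this place.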